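This account rests on a few compounds, and the source may have more. Where it says the series, first, only, none or still open, it means among the compounds named here.

Measured compounds:
Compound 1 `CCCc1nc2c(C)cc(NC(=O)c3ccccc3)cc2n1Cc1ccc(-c2ccccc2C(=O)O)cc1` — 6 nM
Compound 2 `CCCc1nc2c(C)cc(NC(=O)c3ccc(C)cc3)cc2n1Cc1ccc(-c2ccccc2C(=O)O)cc1` — > 10000 nM

In an assay on isolated protein for displacement of a labelled ligand from Type-2 angiotensin II receptor (Homo sapiens), with a stated time of 180 min (a lower number here means a stronger inhibitor, a higher number a weaker inhibitor), compound 1 gives 6 nM. For compound 2 the assay reports only a limit, > 10000 nM, so compound 2 stands at the weak end of the two values shown, as the line the limit of > 10000 nM in this assay, at which 1 of the 2 values shown sits, records. For the measured compounds named here, the step of an at least 1600-fold higher number from compound 1 to compound 2 (3.22 log units; beyond the scatter) is the only measured step, and it is large.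

Compound 3 `CCCc1nc2c(C)cc(NC(=O)CCc3ccccc3)cc2n1Cc1ccc(-c2ccccc2C(=O)O)cc1` is not yet measured. It differs from compound 2 by phenethyl in place of 4-methylphenyl on a carbonyl carbon. Going by the values given here, no measured step matches this change; the step of an at least 1600-fold higher number from compound 1 to compound 2 (3.22 log units; beyond the scatter) shows only that the group on the carbonyl carbon in this part of the core matters strongly. Since compound 3 removes the methyl that accompanies the loss of potency from compound 1 to compound 2, a lower number than the limit of compound 2 is expected, that is an at least 66-fold lower number from compound 2 to compound 3 (1.82 log units; beyond the scatter). Compound 3 is estimated at 150 nM, within 8 nM to 4000 nM.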

Compound 3, half-maximal inhibitory concentration: 149 nM
Beside the measured number, compound 3's estimate is 1.0-fold (0.00 log units) above it; measured number inside the range.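

With an at least 67-fold lower number from compound 2 to compound 3 (1.82 log units; beyond the scatter), a group larger than phenyl on this carbonyl carbon can still give a measurable value in this assay, so the added size of 4-methylphenyl does not by itself account for the loss seen earlier. Phenethyl does not match phenyl, however, with a 25-fold higher number from compound 1 to compound 3 (1.40 log units; beyond the scatter), and compound 1 remains the strongest of the three. The value of compound 2 is a limit and not a number: the limit of > 10000 nM in this assay, at which 1 of the 3 values shown sits.

The compounds shown leave open how a benzyl group or a longer phenylpropyl chain on this carbonyl carbon would compare with phenethyl. They also leave open whether a methyl on the ring of phenethyl would cost as much as it does on the ring of phenyl, and how a methoxy or chloro group there would behave.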